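A few compounds are considered here, and "the series" means these few. Any claim that something is new, unique, unknown or untested is made for them only; others in the source may bear on it.

Compound 1, `CCCS(=O)(=O)Nc1ccc(F)c(C(=O)c2n[nH]c3ncc(-c4ccccc4C)cc23)c1F`, has the lowest number of the three measured compounds in an assay for binding affinity to dual specificity mitogen-activated protein kinase kinase 4 (Homo sapiens), read by KINOMEscan, tested at 100 nM (on this read-out lower numbers stand for a stronger effect and higher numbers for a weaker effect at the one concentration tested), with a value of 7%. Compound 2, `CCCS(=O)(=O)Nc1ccc(F)c(C(=O)c2n[nH]c3ncc(-c4ccc(Cl)cc4Cl)cc23)c1F`, gives 22%, and compound 3, `CCCS(=O)(=O)Nc1ccc(F)c(C(=O)c2n[nH]c3ncc(-c4cc(Cl)cc(Cl)c4)cc23)c1F`, gives 73%. The new compound 4, `CCCS(=O)(=O)Nc1ccc(F)c(C(=O)c2n[nH]c3ncc(-c4ccc(C(C)C)cc4)cc23)c1F`, differs from compound 1 in that (4-isopropylphenyl in place of 2-methylphenyl on an aromatic carbon). The measured steps that bear on this change are a number 15 percentage points higher from compound 1 to compound 2 (beyond the scatter) and a number 66 percentage points higher from compound 1 to compound 3 (beyond the scatter), both of which replaced the 2-methylphenyl group; the related step of a number 51 percentage points higher from compound 2 to compound 3 (beyond the scatter) shows how strongly the pattern of substitution on that phenyl ring can shift the number. Since every measured departure from 2-methylphenyl raised the number, an increase is expected for compound 4, estimated as a number 38 percentage points higher from compound 1 to compound 4 (beyond the scatter), though its size is uncertain. Compound 4 is therefore expected to give about 45%, within a range from 15% to 85%.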

Compound 4, a percentage reported as activity, at one concentration (the size of the read-out at that concentration, not a potency): 17%
Compound 4: middle estimate off by 28 percentage points, on the high side; the measured number falls inside the stated range.
By their numbers in this assay, from the lowest: compounds 1, 4 and 2 (each within the scatter of the next, the first and the last beyond it); then compound 3.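

In this assay, the 4-isopropylphenyl group stays within the scatter of both the 2-methylphenyl group (a number 10 percentage points higher from compound 1 to compound 4 (within the scatter)) and the 2,4-dichlorophenyl group (a number 5 percentage points lower from compound 2 to compound 4 (within the scatter)), yet it stands far from the 3,5-dichlorophenyl group (a number 56 percentage points lower from compound 3 to compound 4 (beyond the scatter)). Compound 4 thus shows that replacing 2-methylphenyl at this position need not move the number beyond the scatter, as both dichlorophenyl groups did. From the compounds shown here alone, whether an amine, a carboxylic acid or a longer chain on this phenyl ring would behave likewise remains open. No available evidence explains these differences.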